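Adding a 4-Methoxybenzyl Group: One Step Transferred

The source may report more compounds than this note shows. Statements on the series, on what has been measured and on what is new or still open speak of the compounds shown alone.

Of the compounds shown here, three sharing one core have been measured in a functional assay on PC-3 cells (Homo sapiens) for cytotoxicity, read by MTT assay, with a stated time of 72 h; a lower number here means a stronger inhibitor, a higher number a weaker inhibitor. Compound 1 `CN1CCN(c2ccc(NC(=N)c3cc4cnn(C)c4cn3)cc2)CC1` gives 32300 nM. Compound 3 `COc1ccc(Cn2ncc3cc(C(=N)Nc4ccc(N5CCN(C)CC5)cc4)ncc32)cc1`, which carries the difference (4-methoxyphenyl in place of hydrogen on a saturated chain carbon bound to an aromatic nitrogen), gives 6100 nM; the step of a 5.3-fold lower number from compound 1 to compound 3 (0.72 log units; beyond the scatter) is beyond the scatter. Compound 2 `Cn1nc(-c2ccccc2)c2cc(C(=N)Nc3cccc(C(F)(F)F)c3)ncc21` gives 20900 nM, within the scatter of compound 1 and beyond the scatter from compound 3. The difference between the cores of compound 1 and compound 2 is not broken down here. Compound 4 `COc1ccc(Cn2nc(-c3ccccc3)c3cc(C(=N)Nc4cccc(C(F)(F)F)c4)ncc32)cc1` is not yet measured; it differs from compound 2 by 4-methoxyphenyl in place of hydrogen on a saturated chain carbon bound to an aromatic nitrogen, the same change at the same place as in the earlier pair. For compound 4 a similar step a 4.2-fold lower number from compound 2 to compound 4 (0.62 log units; beyond the scatter) is expected, because the earlier step of a 5.3-fold lower number from compound 1 to compound 3 (0.72 log units; beyond the scatter) lies beyond the scatter, though it rests on a single precedent. Compound 4 is therefore estimated at 5000 nM in this assay, between 1500 nM and 15000 nM.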

Compound 4, half-maximal inhibitory concentration: > 50000 nM
Compound 4 was reported as a limit; the forecaster's own chance of this, stated with the estimate: 5%; at least 10-fold (1.00 log units) between middle value and limit.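

In this assay compound 4 is recorded only as a limit, > 50000 nM. On the core of compound 2, the change from methyl to 4-methoxybenzyl gives an at least 2.3-fold higher number from compound 2 to compound 4 (0.37 log units; beyond the scatter), so the lowering seen on the core of compound 1 does not carry over, although two pairs cannot show which difference between the cores decides the outcome. The two results differ in direction: the same change on two cores in this assay, a 5.3-fold lower number (0.72 log units; beyond the scatter) from compound 1 to compound 3 and an at least 2.3-fold higher number (0.37 log units; beyond the scatter) from compound 2 to compound 4, at least 12-fold (1.10 log units) apart, beyond the scatter of two such steps

The compounds shown leave open which of the differences between the two cores matters. They also leave open whether a plain benzyl group or a longer alkyl chain in the same place would follow the step of compound 3 or that of compound 4.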